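A few compounds are considered here, and "the series" means these few. Any claim that something is new, unique, unknown or untested is made for them only; others in the source may bear on it.

In a functional assay on HeLa cells (Homo sapiens) for antiproliferative activity, read by CCK-8 assay, with a stated time of 72 h, tested at 2 uM (on this read-out higher numbers stand for a stronger effect at the one concentration tested and lower numbers for a weaker effect), the three measured compounds stand as follows: compound 1 `Nc1ccccc1NC(=O)c1ccc(CSC(=S)N2CCN(c3ccccc3)CC2)cc1` gives 62.2%; compound 2 `Nc1ccccc1NC(=O)c1ccc(CSC(=S)N2CCc3ccccc32)cc1` gives 38%; compound 3 `Nc1ccccc1NC(=O)c1ccc(CSC(=S)N2CCN(c3ccc(F)cc3)CC2)cc1` gives 60.8%.

Compound 2 holds the lowest of the three numbers, and both compound 3 and compound 1 lie higher by more than the usual scatter. Compound 4 `CCN(Cc1ccncc1)C(=S)SCc1ccc(C(=O)Nc2ccccc2N)cc1` differs from compound 2 in one place: ethyl((pyridin-4-yl)methyl)amino in place of 2,3-dihydro-1H-indol-1-yl on a thiocarbonyl carbon. Among the measured compounds shown here, the only measured step, a number 1.4 percentage points lower from compound 1 to compound 3 (within the scatter), concerns a different part of the molecule and therefore says nothing about an exchange on the thiocarbonyl carbon. For the measured compounds named here, no measured step bears on this change, so the expectation rests on compound 2 alone, with wide uncertainty. Compound 4 is estimated at 47%, within a range from 28% to 66%. The expected step is a number 9 percentage points higher from compound 2 to compound 4 (within the scatter), a rise that may or may not clear the scatter.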

Compound 4, a percentage reported as inhibition, at one concentration (the size of the read-out at that concentration, not a potency): 63.5%
The estimate for compound 4 lay 16.5 percentage points below the measured number, and the stated range covers the measured number.
By their numbers in this assay, from the lowest: compound 2; then compounds 3, 1 and 4 (each within the scatter of the next).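

On the thiocarbonyl carbon, the group attached makes a real difference in this assay: ethyl((pyridin-4-yl)methyl)amino in place of 2,3-dihydro-1H-indol-1-yl gives a number 25.5 percentage points higher from compound 2 to compound 4 (beyond the scatter). Among the compounds shown here, this is the first measured single exchange at this position, and the only earlier step concerned a different part of the molecule. No available evidence explains the rise. Going by these compounds, it remains open whether the ethyl group or the pyridine ring matters more, and what a morpholine or a simple dimethylamino group would give on the same carbon.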